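Replacing 1-methyl-1H-pyrazol-5-yl with 1H-pyrazol-1-yl

A few compounds are considered here, and "the series" means these few. Any claim that something is new, unique, unknown or untested is made for them only; others in the source may bear on it.

Compound 1 `CCN(c1ccc(C#N)c(Cl)c1)c1cc(-c2cnc3ccccc3c2)ccc1C`: 3570 nM
Compound 2 `CCN(c1ccc(C#N)c(Cl)c1)c1cc(-c2ccnn2C)ccc1C`: 7290 nM

In a functional assay on PC-3 cells (Homo sapiens) for antiproliferative activity, read by CCK-8 assay, with a stated time of 6 days (on this read-out lower numbers stand for stronger inhibition and higher numbers for weaker inhibition), compound 2 gives 7290 nM, the higher and therefore weaker of the two numbers, and the gap to compound 1 at 3570 nM lies beyond the usual scatter. Compound 3 `CCN(c1ccc(C#N)c(Cl)c1)c1cc(-n2cccn2)ccc1C` carries 1H-pyrazol-1-yl in place of 1-methyl-1H-pyrazol-5-yl on an aromatic carbon. For the measured compounds named here, no measured pair shows a change of this kind, so the expectation is only tentative. In this assay, the expected 1.2-fold lower number from compound 2 to compound 3 (0.08 log units; within the scatter) is no larger than the scatter, with no clear direction. Compound 3 is estimated at 6000 nM, with an expected range from 2500 nM to 14000 nM.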

Compound 3, half-maximal inhibitory concentration: 15700 nM
Estimate against measurement, compound 3: 2.6-fold (0.42 log units) below; the measured number lies above the stated range.
By their numbers in this assay, from the lowest: compound 1; then compound 2; then compound 3.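

In this assay there is a 2.2-fold higher number from compound 2 to compound 3 (0.33 log units; beyond the scatter) when 1H-pyrazol-1-yl replaces 1-methyl-1H-pyrazol-5-yl on this aromatic carbon. The two groups are both five-membered aromatic rings with the same counts of hydrogen-bond donors and acceptors, yet they are not interchangeable here. No measured evidence explains the difference. The entering group has one heavy atom fewer and is also joined differently, and these two differences cannot be separated with these compounds. As far as these compounds go, it also remains open how an amine or a carboxylic acid would behave at this position.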